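Replacing one large group with fluorine: working notes

A few compounds are considered here, and "the series" means these few. Any claim that something is new, unique, unknown or untested is made for them only; others in the source may bear on it.

Of the compounds shown here, two have values so far in a functional assay on DU-145 cells (Homo sapiens) for antiproliferative activity, read by propidium iodide staining, with a stated time of 96 h; on this read-out higher numbers stand for weaker inhibition and lower numbers for stronger inhibition. Compound 1 (`CC(O)(CSc1ccccc1OC(F)(F)F)C(=O)Nc1cccc(S(F)(F)(F)(F)F)c1`) gives 17500 nM, and compound 2 (`CC(O)(CS(=O)(=O)c1ccc(S(F)(F)(F)(F)F)cc1)C(=O)Nc1ccc(S(F)(F)(F)(F)F)cc1`) gives 28900 nM. These two values lie within the scatter of each other, so compound 2 cannot be ranked against compound 1. Going by the values given here, the two compounds differ in more than one place, and no single-change step between measured compounds is available.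

Compound 3 (`CC(O)(CS(=O)(=O)c1ccc(F)cc1)C(=O)Nc1ccc(S(F)(F)(F)(F)F)cc1`) has not yet been measured. It differs from compound 2 in one place: one fluorine atom in place of a group of 6 heavy atoms (5 fluorine, 1 sulfur; no ring), on an aromatic carbon. One fluorine atom stands in place of the larger group, on an aromatic carbon.

Among the compounds with values here, the only guide is the narrow spread of the two known values, with compound 1 at 17500 nM and compound 2 at 28900 nM, although their structures differ in more than one place. No step beyond the scatter is therefore expected in this assay, and no direction can be favoured. The estimated step is a 1.0-fold higher number from compound 2 to compound 3 (0.02 log units; within the scatter). For compound 3 the expected value is 30000 nM, with an estimated range of 12000 nM to 70000 nM.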

Compound 3, half-maximal inhibitory concentration: 27700 nM
Beside the measured number, compound 3's estimate is 1.1-fold (0.03 log units) above it, within the range that was stated.
By their numbers in this assay, from the lowest: compounds 1, 3 and 2 (each within the scatter of the next).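

In this assay, the series now has its first step that can be read at a single position: a 1.0-fold lower number from compound 2 to compound 3 (0.02 log units; within the scatter), with one fluorine atom in place of the group of 6 heavy atoms (5 fluorine, 1 sulfur; no ring), on an aromatic carbon para to a large group. Compounds 1 and 2 differ in more than one place and could not show this; the new step shows that, on this read-out, the two substituents at this position cannot be told apart, even though they differ widely in heavy-atom count. No measurement at hand bears on the reason for this result.

On these data alone, whether the same holds for other groups on this aromatic carbon, such as an amine, a carboxylic acid or a methoxy group, remains open. Compounds 1, 3 and 2 each lie within the scatter of the next, so the compounds shown also leave open whether this position would matter on a core that gives clearly lower numbers in this assay.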